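The compounds below may be only part of what the source reports. "The series", "measured", "known", "first", "only" and "open" are said of these compounds alone.

Notes on the series. The shared core is varied at the group on the saturated ring carbon. Compound 1 `COc1cc2nc(N3CCC(C(=O)NCCO)CC3)nc(N)c2cc1OC` gives 1.73 nM in an assay on isolated protein for displacement of a labelled ligand from Adrenergic receptor alpha-1 (Rattus norvegicus); a higher number here means a weaker inhibitor, a lower number a stronger inhibitor; compound 2 `CCN(CC)C(=O)C1CCN(c2nc(N)c3cc(OC)c(OC)cc3n2)CC1` gives 1.11 nM in this assay; compound 3 `COc1cc2nc(N3CCC(C(=O)Nc4ccccc4)CC3)nc(N)c2cc1OC` gives 0.47 nM, the lowest number of the three, separated from the others beyond the scatter. The steps of a 3.7-fold lower number from compound 1 to compound 3 (0.57 log units; beyond the scatter) and a 2.4-fold lower number from compound 2 to compound 3 (0.37 log units; beyond the scatter) both run toward the phenyl on the amide nitrogen. Compound 4 `CCCNC(=O)CC1CCN(c2nc(N)c3cc(OC)c(OC)cc3n2)CC1` carries (propylcarbamoyl)methyl in place of phenylcarbamoyl on a saturated ring carbon. For the measured compounds named here, its amide again bears an alkyl group, so those two steps bear on it, while the (propylcarbamoyl)methyl arrangement itself has no measured precedent; a modest step upward is expected, roughly a 2.8-fold higher number from compound 3 to compound 4 (0.44 log units; beyond the scatter). Compound 4 is therefore estimated at 1.3 nM, with a range from 0.6 nM to 3 nM.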

Compound 4, inhibition constant: 0.65 nM
The estimate for compound 4 lay 2.0-fold (0.30 log units) above the measured number, and the stated range covers the measured number.
By their numbers in this assay, from the lowest: compounds 3, 4, 2 and 1 (each within the scatter of the next, the first and the last beyond it).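

At the saturated ring carbon, (propylcarbamoyl)methyl can stand in place of phenylcarbamoyl with no change beyond the scatter (a 1.4-fold higher number from compound 3 to compound 4 (0.14 log units; within the scatter)), so a phenyl on the amide nitrogen is not required for a number in this range. For the compounds shown here, the same holds against diethylcarbamoyl (a 1.7-fold lower number from compound 2 to compound 4 (0.23 log units; within the scatter)), and only the step from (2-hydroxyethyl)carbamoyl lies beyond the scatter (a 2.7-fold lower number from compound 1 to compound 4 (0.43 log units; beyond the scatter)). No measurement shown gives a reason for these steps.

This change alters both the group on the amide nitrogen and the link to the ring, and the two cannot be read apart. Propylcarbamoyl or (phenylcarbamoyl)methyl on the same carbon would separate them, and a carboxylic acid there remains an open question.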